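The source may report more compounds than this note shows. Statements on the series, on what has been measured and on what is new or still open speak of the compounds shown alone.

Of the compounds shown here, three built on one shared core have so far been tested in a functional assay on KB cells (Homo sapiens) for antiproliferative activity, read by sulforhodamine B assay, with a stated time of 3 days; on this read-out lower numbers stand for an effect already at smaller amounts and higher numbers for an effect only at larger amounts of compound. Compound 3 `CCC1=C(O)c2c(oc(-c3cccc(OC)c3)cc2=O)C(CC)(CC)C1=O` gives 13.3 uM in this assay, the lowest of the two plain numbers recorded. Compound 1 `CCC1=C(O)c2c(oc(-c3ccc(CC)cc3)cc2=O)C(CC)(CC)C1=O` gives 21.9 uM in this assay; the step of a 1.6-fold lower number from compound 1 to compound 3 (0.22 log units; within the scatter) stays within the scatter, so these two cannot be placed in order. Compound 2 `CCCc1ccc(-c2cc(=O)c3c(o2)C(CC)(CC)C(=O)C(CC)=C3O)cc1` yields only a limit in this assay, > 53 uM. That limit is the limit of > 53 uM in this assay, at which 1 of the 3 values shown sits. The step of an at least 2.4-fold higher number from compound 1 to compound 2 (0.38 log units; beyond the scatter) shows that adding methyl in place of hydrogen on a saturated chain carbon, two bonds along the chain from an aromatic carbon, weakened the effect. In the other direction, an at least 3.9-fold lower number from compound 2 to compound 3 (0.60 log units; beyond the scatter), the number fell at least modestly.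

Compound 4 `CCC1=C(O)c2c(oc(-c3ccc(C)c(Cl)c3)cc2=O)C(CC)(CC)C1=O` has not yet been measured in this assay. Its structural change from compound 3 is 3-chloro-4-methylphenyl in place of 3-methoxyphenyl on an aromatic carbon. The group that enters brings a methyl on its aromatic ring together with a chlorine, and the two measured steps that bear on it, a 1.6-fold lower number from compound 1 to compound 3 (0.22 log units; within the scatter) and an at least 3.9-fold lower number from compound 2 to compound 3 (0.60 log units; beyond the scatter), point the same way: swapping 3-methoxyphenyl for an alkyl-bearing phenyl gave an unchanged or higher number. A modest rise is therefore expected, a 2.0-fold higher number from compound 3 to compound 4 (0.29 log units; within the scatter). Compound 4 is estimated at 26 uM in this assay, within a range of 10 uM to 60 uM.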

Compound 4, concentration for half-maximal effect: 39 uM
Beside the measured number, compound 4's estimate is 1.5-fold (0.18 log units) below it, within the range that was stated.
By their numbers in this assay, from the lowest: compounds 3, 1 and 4 (each within the scatter of the next, the first and the last beyond it). At a limit, above all of these: compound 2.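

In this assay, for the compounds shown here, the step from one group to the other (a 2.9-fold higher number from compound 3 to compound 4 (0.47 log units; beyond the scatter)) is the first change at this aromatic carbon, next to the ring oxygen, that separates two plain numbers beyond the scatter, and it comes with the same count of heavy atoms on both sides: an oxygen-bearing methoxy group and its one hydrogen-bond acceptor leave, while a chlorine and a methyl enter on the same kind of ring. The two alkyl- or halogen-bearing rings with plain numbers stay together, since the step from 4-ethylphenyl to 3-chloro-4-methylphenyl (a 1.8-fold higher number from compound 1 to compound 4 (0.25 log units; within the scatter)) lies within the scatter and puts these two compounds in no order. Going by these compounds alone, compound 2 gives only a limit, so its step (an at least 1.3-fold lower number from compound 2 to compound 4 (0.13 log units; that floor lies within the scatter)) sets no order for that pair: the limit of > 53 uM in this assay, at which 1 of the 4 values shown sits.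

Chlorine and methyl enter together here, and the compounds shown do not tell which of them goes with the higher number. From the compounds shown here alone, how a phenyl ring carrying an amine or a carboxylic acid at this place would read in this assay also stays open.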